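A few compounds are considered here, and "the series" means these few. Any claim that something is new, unique, unknown or untested is made for them only; others in the source may bear on it.

Measured so far in a functional assay on MDA-MB-231 cells (Homo sapiens) for antiproliferative activity, read by sulforhodamine B assay, with a stated time of 48 h; a lower number here means a stronger inhibitor, a higher number a weaker inhibitor:
- compound 1 `NS(=O)(=O)c1ccc(N/C(S)=N\c2ccnc3cc(C(F)(F)F)ccc23)cc1`: 52900 nM
- compound 2 `O=S(=O)(Nc1ncccn1)c1ccc(N/C(S)=N\c2ccnc3cc(C(F)(F)F)ccc23)cc1`: 45200 nM

Within the data shown here, compound 2 holds the lower of these two numbers, yet the only measured step, a 1.2-fold lower number from compound 1 to compound 2 (0.07 log units; within the scatter), lies within the scatter, so the two compounds are not truly separated. Compound 3 `COc1cc(NS(=O)(=O)c2ccc(N/C(S)=N\c3ccnc4cc(C(F)(F)F)ccc34)cc2)nc(OC)n1` is not yet measured; it differs from compound 2 by 2,6-dimethoxypyrimidin-4-yl in place of pyrimidin-2-yl on a sulfonamide nitrogen. Among the measured compounds shown here, no measured step covers this exchange, and the sole step available, which also altered the group on the sulfonamide nitrogen, stayed within the scatter. The expectation for compound 3 is therefore no shift beyond the scatter, a 1.1-fold lower number from compound 2 to compound 3 (0.05 log units; within the scatter). The estimate for compound 3 is 40000 nM, within 15000 nM to 110000 nM.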

Compound 3, half-maximal inhibitory concentration: 52100 nM
For compound 3 the middle estimate is 1.3-fold (0.11 log units) below the measured one; the range from low to high includes it.
By their numbers in this assay, from the lowest: compounds 2, 3 and 1 (each within the scatter of the next).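

In this assay, placing 2,6-dimethoxypyrimidin-4-yl on the sulfonamide nitrogen in place of pyrimidin-2-yl gives a 1.2-fold higher number from compound 2 to compound 3 (0.06 log units; within the scatter) and in place of hydrogen gives a 1.0-fold lower number from compound 1 to compound 3 (0.01 log units; within the scatter) and so neither exchange separates the compounds. This position has now carried hydrogen and two different pyrimidine rings, one of them with two methoxy groups, and the three compounds remain within the scatter of one another. Nothing available here bears on why these numbers stay together.

The compounds shown leave open whether an acetyl group or a longer alkyl chain on this nitrogen would move the number beyond the scatter. They also leave open whether replacing the trifluoromethyl group on the shared core with a nitrile would do so.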